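Removing Bromo from the Aryl Ring: What Compound 4 May Show

The source may report more compounds than this note shows. Statements on the series, on what has been measured and on what is new or still open speak of the compounds shown alone.

Compound 1, `COc1ccc(CN(C(=O)CSC(=S)N2CCc3ccccc32)c2cc(OC)c(OC)c(OC)c2)cc1`, gives 8410 nM in a functional assay on MGC-803 cells (Homo sapiens) for inhibition, read by CCK-8 assay, with a stated time of 48 h; a lower number here means a stronger inhibitor, a higher number a weaker inhibitor.
Compound 2, `COc1ccc(CN(C(=O)CSC(=S)N2CCc3cc(Br)ccc32)c2cc(OC)c(OC)c(OC)c2)cc1`, reaches only the limit > 20000 nM in this assay.
Compound 3, `COc1ccc(CN(C(=O)CSC(=S)N2CCN(C(=O)OC(C)(C)C)CC2)c2ccc(Br)cc2)cc1`, likewise reaches only the limit > 20000 nM in this assay.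

Compound 1 differs from compound 2 by hydrogen in place of bromo on an aromatic carbon, and this gave an at least 2.3-fold lower number from compound 2 to compound 1 (0.37 log units; beyond the scatter).

Compound 4, `COc1ccc(CN(C(=O)CSC(=S)N2CCN(C(=O)OC(C)(C)C)CC2)c2ccccc2)cc1`, differs from compound 3 by hydrogen in place of bromo on an aromatic carbon. The difference between the core of compound 3 and the core of compound 2 is not broken down here. The two places are not the same: in compound 2 the ring is part of a fused system, meta and para to a fused ring, while in compound 3 it is a six-membered ring of carbon only, para to a large group, so this is the same kind of change rather than the same change.

For compound 4 a step of an at least 1.3-fold lower number from compound 3 to compound 4 (0.12 log units; that floor lies within the scatter) is expected in this assay, resting on the earlier step of an at least 2.3-fold lower number from compound 2 to compound 1 (0.37 log units; beyond the scatter) and on (the limit of > 20000 nM in this assay, at which 2 of the 3 values shown sit), which leaves the starting point for compound 3 unknown. Compound 4 is estimated at 15000 nM, expected between 4000 nM and 40000 nM.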

Compound 4, half-maximal inhibitory concentration: > 20000 nM
Compound 4 was reported as a limit; the forecaster's own chance of this, stated with the estimate: 50%; at least 1.3-fold (0.12 log units) between middle value and limit.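

Compound 3 and compound 4 both stop at a limit in this assay rather than a number, so no step between them can be read: the limit of > 20000 nM in this assay, at which 3 of the 4 values shown sit.

The compounds shown leave open whether going from 4-bromophenyl to phenyl changes anything on the core of compound 3.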